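The compounds below may be only part of what the source reports. "The series", "measured", "known", "first", "only" and "open" are said of these compounds alone.

In an ADME assay on microsomes from liver (Mus musculus) for metabolic stability, with a stated time of 10 min (a higher number here means that more of the compound is left, a lower number that less of the compound is left), compound 1 `O=C(O)C12CCC(C(=O)N3CC[C@](c4ccc(C(F)(C(F)(F)F)C(F)(F)F)cc4)(S(=O)(=O)c4ccc(F)cc4)C3)(CC1)C2` gives "not determined" (no result reported), so it offers no number for comparison. Compound 2 `O=C(O)C12CCC(C(=O)N3CC[C@](c4ccc(C(F)(C(F)(F)F)C(F)(F)F)cc4)(S(=O)(=O)c4ccc(F)cc4)C3)(CC1)CC2` gives 73%, and compound 3 `O=C(O)C12CCC(C(=O)N3CC[C@](c4ccc(C(F)(C(F)(F)F)C(F)(F)F)cc4)(S(=O)(=O)c4ccc(F)cc4)C3)(CC1)OC2` gives 94%, the higher of the two numbers. Compound 4 `O=C([C@H]1CC[C@H](CO)CC1)N1CC[C@](c2ccc(C(F)(C(F)(F)F)C(F)(F)F)cc2)(S(=O)(=O)c2ccc(F)cc2)C1` shares their core but differs at the carbonyl carbon: a group of 8 heavy atoms (7 carbon, 1 oxygen; one six-membered non-aromatic ring of carbon only) in place of a group of 11 heavy atoms (8 carbon, 3 oxygen; one six-membered non-aromatic ring of carbon only, one six-membered non-aromatic ring with 1 hetero atom), on a carbonyl carbon. Going by the values given here, only one measured step bears on this site, a number 21 percentage points higher from compound 2 to compound 3 (beyond the scatter), and it shows that the group there can move the read-out beyond the scatter. Among the compounds with values here, no measured compound carries the 4-(hydroxymethyl)cyclohexyl group, so the guide is loose. Compound 3, at 94%, has little room to rise, so a fall of similar size is expected, a number 19 percentage points lower from compound 3 to compound 4 (beyond the scatter). For compound 4 the estimated value is 75%, within an expected range of 50% to 93%.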

Compound 4, percent of the compound remaining: 63%
Compound 4: middle estimate off by 12 percentage points, on the high side, within the range that was stated.
By their numbers in this assay, from the lowest: compounds 4 and 2 (each within the scatter of the next); then compound 3.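

Putting 4-(hydroxymethyl)cyclohexyl on the carbonyl carbon gives a number 31 percentage points lower from compound 3 to compound 4 (beyond the scatter), so in this assay this position can lose as well as gain. Set against the other measured group, the same change gives a number 10 percentage points lower from compound 2 to compound 4 (within the scatter), so compound 4 and compound 2 cannot be told apart and only compound 3 stands out. No measurement shown explains these differences.

On these data alone, whether the hydroxymethyl group itself matters stays open. A plain cyclohexyl group, or a cyclohexyl group carrying a carboxylic acid, could separate the effect of the ring from that of its substituent.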